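The source may hold more compounds than are shown below. What is called first, only, known or untested is meant among the compounds shown, and "the series" means these compounds.

Measured compounds, with their values in an ADME assay for permeability, using PAMPA, with a stated time of 4 h; on this read-out lower numbers stand for lower permeability and higher numbers for higher permeability:

- compound 1 `Cc1ccc(Oc2ccc3nc(COc4cccc(C(=O)O)c4)n(C)c3n2)c(C)c1` gives 28.8 10^-6 cm/s
- compound 2 `Cn1c(COc2cccc(C(=O)O)c2)nc2ccc(Oc3ccc(Cl)cn3)cc21` gives 16.2 10^-6 cm/s
- compound 3 `Cc1ccnc(Oc2ccc3nc(COc4cccc(C(=O)O)c4)n(C)c3c2)c1` gives 3.5 10^-6 cm/s

Compound 3 holds the lowest of the three numbers in this assay, with compound 2 its nearest neighbour and compound 1 the furthest. Among the measured compounds shown here, the only step on record, a 4.6-fold lower number from compound 2 to compound 3 (0.67 log units; beyond the scatter), concerns a swap of the pyridinyl group on the aryl oxygen and is therefore the nearest guide to the next change.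

Compound 4 `Cc1cc(F)cnc1Oc1ccc2nc(COc3cccc(C(=O)O)c3)n(C)c2c1`, not yet measured, differs from compound 3 in one place: 5-fluoro-3-methylpyridin-2-yl in place of 4-methylpyridin-2-yl on an oxygen on an aromatic ring. For the measured compounds named here, no measured pair shows exactly this change; the one precedent, the step from compound 2 to compound 3, shows that swapping one substituted pyridin-2-yl for another on this oxygen can move this assay by a modest but real amount. The expected step of a 1.9-fold higher number from compound 3 to compound 4 (0.27 log units; within the scatter) is taken as a small rise, because compound 3 gives 3.5 10^-6 cm/s, which sits at the bottom of the range, and compound 2 with a halogen on the pyridinyl ring gives 16.2 10^-6 cm/s. The estimate for compound 4 in this assay is 6.5 10^-6 cm/s, within 2.5 10^-6 cm/s to 17 10^-6 cm/s.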

Compound 4, apparent permeability: 8.3 10^-6 cm/s
Estimate against measurement, compound 4: 1.3-fold (0.11 log units) below, within the range that was stated.
By their numbers in this assay, from the lowest: compound 3; then compounds 4, 2 and 1 (each within the scatter of the next, the first and the last beyond it).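

In this assay, 5-fluoro-3-methylpyridin-2-yl in place of 4-methylpyridin-2-yl gives a 2.4-fold higher number from compound 3 to compound 4 (0.38 log units; beyond the scatter), so a second group on this aromatic-ring oxygen now reads beyond the scatter against compound 3, after the 5-chloropyridin-2-yl of compound 2. The two halogen-bearing groups are not separated, since a 2.0-fold lower number from compound 2 to compound 4 (0.29 log units; within the scatter) stays inside the scatter, and among these three compounds the only group carrying no halogen belongs to compound 3. No measurement of any underlying property is available to account for these steps.

The fluorine and the extra methyl enter together in compound 4, so their separate shares in the step from compound 3 cannot be read. On these data alone, how a pyridin-2-yl group bearing an amine or a nitrile would stand in this assay also remains open.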